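Side-chain removal at the inner position of the sulfonamide peptides

This account rests on a few compounds, and the source may have more. Where it says the series, first, only, none or still open, it means among the compounds named here.

Compound 1 `CSCC[C@H](NC(=O)[C@H](CC(C)C)NC(=O)[C@H](CC(C)C)NC(=O)CC[C@H](NS(=O)(=O)c1ccc(Cl)c(C(F)(F)F)c1)C(=O)O)C(N)=O` gives 780 nM in an assay on isolated protein for inhibition of Matrilysin (Homo sapiens), read by fluorescence, with a stated time of 15 min; a higher number here means a weaker inhibitor, a lower number a stronger inhibitor. Compound 3 `CSCC[C@H](NC(=O)[C@H](CC(C)C)NC(=O)[C@H](C)NC(=O)CC[C@H](NS(=O)(=O)c1ccc(Cl)c(C(F)(F)F)c1)C(=O)O)C(N)=O` gives 440 nM, and compound 2 `CC(C)C[C@H](NC(=O)CNC(=O)CC[C@H](NS(=O)(=O)c1ccc(Cl)c(C(F)(F)F)c1)C(=O)O)C(=O)N[C@H](C(N)=O)C(C)C` gives 56 nM. Among the measured compounds shown here, compound 3 stands second highest of the three numbers, nearest compound 1 and furthest from compound 2; compound 2 and compound 3 differ in more than one place, so their two values show only that compound 2 lies well lower. Compound 4 `CSCC[C@H](NC(=O)[C@H](CC(C)C)NC(=O)CNC(=O)CC[C@H](NS(=O)(=O)c1ccc(Cl)c(C(F)(F)F)c1)C(=O)O)C(N)=O` differs from compound 3 by hydrogen in place of methyl on a saturated chain carbon bound to an amide-type nitrogen and a carbonyl carbon. For the measured compounds named here, the only measured step at this position is a 1.8-fold lower number from compound 1 to compound 3 (0.25 log units; within the scatter), which was within the scatter. For compound 4, therefore, no step beyond the scatter is expected in this assay, with at most a slight lean lower. The expected step for compound 4 is a 1.4-fold lower number from compound 3 to compound 4 (0.14 log units; within the scatter). Compound 4 is estimated at 320 nM, range 130 nM to 800 nM.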

Compound 4, half-maximal inhibitory concentration: 120 nM
Estimate against measurement, compound 4: 2.7-fold (0.43 log units) above; the whole stated range lies above it.
By their numbers in this assay, from the lowest: compound 2; then compound 4; then compounds 3 and 1 (each within the scatter of the next).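

In this assay hydrogen in place of methyl on this carbon gives a 3.7-fold lower number from compound 3 to compound 4 (0.56 log units; beyond the scatter) and hydrogen in place of isobutyl gives a 6.5-fold lower number from compound 1 to compound 4 (0.81 log units; beyond the scatter) so the position does respond to its side chain, which the earlier step within the scatter did not show. Of the three compounds sharing the rest of the structure, only compound 4, with hydrogen here, stands apart. With hydrogen on this carbon in both compounds, 2-(methylsulfanyl)ethyl in place of isopropyl on another carbon of the same description gives a 2.1-fold higher number from compound 2 to compound 4 (0.33 log units; beyond the scatter) so a second place also moves the number.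

From the compounds shown here alone, whether a hydroxymethyl or aminomethyl group on this carbon would hold the number of compound 4 stays open. No evidence on the reason for these steps is at hand.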